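Furan-3-yl to 1-benzofuran-2-yl on two nucleoside cores

The source may hold more compounds than are shown below. What is called first, only, known or untested is meant among the compounds shown, and "the series" means these compounds.

Measured compounds:
Compound 1 `O=c1[nH]cnc2c1c(-c1ccoc1)cn2[C@@H]1O[C@H](CO)[C@@H](O)[C@H]1O`: 12500 nM
Compound 2 `Cc1nc(N)c2c(-c3ccoc3)cn([C@@H]3O[C@H](CO)[C@@H](O)[C@H]3O)c2n1`: > 20000 nM
Compound 3 `O=c1[nH]cnc2c1c(-c1cc3ccccc3o1)cn2[C@@H]1O[C@H](CO)[C@@H](O)[C@H]1O`: > 20000 nM

In a functional assay on K562 cells (Homo sapiens), read by MTT assay, with a stated time of 72 h (on this read-out lower numbers stand for stronger inhibition and higher numbers for weaker inhibition), compound 1 gives 12500 nM. Compound 2 reaches only a limit of the assay, > 20000 nM. Compound 3 likewise reaches only a limit, > 20000 nM. The change from compound 1 to compound 3, (1-benzofuran-2-yl in place of furan-3-yl on an aromatic carbon), makes an at least 1.6-fold higher number from compound 1 to compound 3 (0.20 log units; that floor lies within the scatter); its floor rests on (the limit of > 20000 nM in this assay, at which 2 of the 3 values shown sit). The difference between the cores of compound 1 and compound 2 is not broken down here. Compound 4 `Cc1nc(N)c2c(-c3cc4ccccc4o3)cn([C@@H]3O[C@H](CO)[C@@H](O)[C@H]3O)c2n1` carries the same change on the core of compound 2, (1-benzofuran-2-yl in place of furan-3-yl on an aromatic carbon). The step from compound 2 to compound 4 is expected to be a step that the limit leaves unreadable from compound 2 to compound 4, because compound 2 already sits at the limit > 20000 nM and the same change gave an at least 1.6-fold higher number from compound 1 to compound 3 (0.20 log units; that floor lies within the scatter). Compound 4 is therefore estimated at 35000 nM, expected between 18000 nM and 90000 nM, most likely reported only as a limit.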

Compound 4, half-maximal inhibitory concentration: 15700 nM
The estimate for compound 4 lay 2.2-fold (0.35 log units) above the measured number; the whole stated range lies above it.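

In this assay compound 4 gives a measured number, 15700 nM. The change from furan-3-yl to 1-benzofuran-2-yl gives an at least 1.2-fold lower number from compound 2 to compound 4 (0.10 log units; that floor lies within the scatter), and the comparison with the other core stays incomplete: the same change on two cores in this assay, an at least 1.6-fold higher number (0.20 log units; that floor lies within the scatter) from compound 1 to compound 3 and an at least 1.2-fold lower number (0.10 log units; that floor lies within the scatter) from compound 2 to compound 4; the limit leaves it open whether they differ Neither step has a true size, since each rests on a limit: the limit of > 20000 nM in this assay, at which 2 of the 4 values shown sit. The pair does not show whether the effect of the change carries over between the two cores or differs between them.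

From the compounds shown here alone, a phenyl group or a thiophen-2-yl group on the same aromatic carbon remains open on both cores. So does whether either group would give numbers clear of the limit on both.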